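This account rests on a few compounds, and the source may have more. Where it says the series, first, only, none or still open, it means among the compounds named here.

Measured so far:
compound 1 `NS(=O)(=O)Oc1ccc2c(c1)CN(C(=O)c1ccc(N3CCN(Cc4ccccc4)CC3)cc1)CC2` — 20.8%
compound 2 `CCN(Cc1ccncc1)c1cccc(C(=O)N2CCc3ccc(OS(N)(=O)=O)cc3C2)c1` — 33.3%

Both numbers come from an assay on HEK293 cells for inhibition of Steryl-sulfatase (Homo sapiens), tested at 0.1 uM; a lower number here means a weaker effect, a higher number a stronger effect of the compound at the concentration tested. Compound 2 stands highest of the two; the nearest, compound 1, lies lower by a margin beyond the usual scatter, but the two structures differ in several places, so no single step can be read from them.

Compound 3 `CCN(Cc1cccnc1)c1cccc(C(=O)N2CCc3ccc(OS(N)(=O)=O)cc3C2)c1` differs from compound 2 in one place: pyridin-3-yl in place of pyridin-4-yl on a saturated chain carbon bound to a nitrogen on an aromatic ring. Among the measured compounds shown here, no measured pair covers a change of this kind, so in this assay no step beyond the scatter is expected. The expected step is a number 3.3 percentage points lower from compound 2 to compound 3 (within the scatter), within the scatter. Compound 3 is estimated at 30%, with a range from 15% to 45%.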

Compound 3, a percentage reported as inhibition, at one concentration (the size of the read-out at that concentration, not a potency): 14.3%
Beside the measured number, compound 3's estimate is 15.7 percentage points above it; the measured number lies below the stated range.
By their numbers in this assay, from the lowest: compounds 3 and 1 (each within the scatter of the next); then compound 2.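

With pyridin-3-yl in place of pyridin-4-yl on a saturated chain carbon bound to a nitrogen on an aromatic ring, this assay shows a number 19 percentage points lower from compound 2 to compound 3 (beyond the scatter). The two groups hold the same atoms, so this position responds to how the pyridine is joined and not only to which atoms it carries. Nothing at hand gives a reason for this step.

Open, from the compounds shown here alone, is how pyridin-2-yl would read on the same carbon. Also open, going by these compounds, is whether a methyl or a propyl group in place of the ethyl on that nitrogen would move the read-out.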